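This account rests on a few compounds, and the source may have more. Where it says the series, first, only, none or still open, it means among the compounds named here.

Among the measured compounds shown here, in a functional assay on HepG2 cells (Homo sapiens) for inhibition, read by MTT assay, with a stated time of 48 h (a lower number here means a stronger inhibitor, a higher number a weaker inhibitor), three compounds with a shared core have numbers so far. Compound 1 (`COc1cc(-c2nccn3cc(-c4ccc(Cl)cc4)nc23)cc(OC)c1OC`), bearing 4-chlorophenyl, gives 475 nM. Compound 2 (`COc1cc(-c2nccn3cc(-c4ccc5[nH]ccc5c4)nc23)cc(OC)c1OC`), bearing 1H-indol-5-yl, gives 146 nM. Compound 3 (`COc1cc(-c2nccn3cc(-c4ccccc4)nc23)cc(OC)c1OC`), bearing phenyl, gives 267 nM. Compound 3 cannot be told apart from either of the others, as shown by a 1.8-fold lower number from compound 1 to compound 3 (0.25 log units; within the scatter) and a 1.8-fold higher number from compound 2 to compound 3 (0.26 log units; within the scatter). Only a 3.3-fold lower number from compound 1 to compound 2 (0.51 log units; beyond the scatter) exceeds the scatter.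

Compound 4 (`COc1cc(-c2nccn3cc(-c4ccc(C(F)(F)F)cc4)nc23)cc(OC)c1OC`) has trifluoromethyl in place of hydrogen on an aromatic carbon, para to a large group: trifluoromethyl in place of hydrogen on an aromatic carbon. For the measured compounds named here, the nearest precedent is the exchange of chloro and hydrogen on an aromatic carbon, seen in a 1.8-fold lower number from compound 1 to compound 3 (0.25 log units; within the scatter). Read backwards, that small step points to a slight rise in the number on adding a group to the phenyl, though no measured compound carries trifluoromethyl. The estimated change is a 1.5-fold higher number from compound 3 to compound 4 (0.18 log units; within the scatter), which is not expected to pass beyond the scatter. For compound 4, the expected value in this assay is 400 nM, with an estimated range of 170 nM to 900 nM.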

Compound 4, half-maximal inhibitory concentration: 2630 nM
For compound 4 the middle estimate is 6.6-fold (0.82 log units) below the measured one; measured number above the stated range.
By their numbers in this assay, from the lowest: compounds 2, 3 and 1 (each within the scatter of the next, the first and the last beyond it); then compound 4.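

In this assay, among the compounds shown here, the aromatic carbon para to a large group proves sensitive to what it carries, which the earlier compounds did not show: chloro there stayed within the scatter of hydrogen, while trifluoromethyl gives (a 9.9-fold higher number from compound 3 to compound 4 (0.99 log units; beyond the scatter)). The change is also specific to the group, since trifluoromethyl in place of chloro at that same carbon still gives (a 5.5-fold higher number from compound 1 to compound 4 (0.74 log units; beyond the scatter)). For the compounds shown here, compound 4 stands furthest from the 1H-indol-5-yl compound, at (an 18-fold higher number from compound 2 to compound 4 (1.26 log units; beyond the scatter)), and this is the only large step in the set. Nothing measured here accounts for the rise. The compounds shown leave open whether a methoxy, a nitrile or an amine at this carbon would follow chloro or trifluoromethyl. They also leave open whether a carboxylic acid there would be tolerated.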